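Extending the Dimethylamino Chain Once More

The compounds below may be only part of what the source reports. "The series", "measured", "known", "first", "only" and "open" are said of these compounds alone.

compound 1 `CN(C)CCn1c(N)c(-c2nc3cc(Cl)ccc3[nH]2)c2nc(C#N)c(C#N)nc21`: > 50000 nM
compound 2 `CN(C)CCCn1c(N)c(-c2nc3cc(Cl)ccc3[nH]2)c2nc(C#N)c(C#N)nc21`: 16500 nM

Both compounds were tested in a functional assay on HeLa cells (Homo sapiens) for antiproliferative activity, read by MTT assay, with a stated time of 48 h; a higher number here means a weaker inhibitor, a lower number a stronger inhibitor. For compound 1, the value > 50000 nM is a limit of the assay and not a number. Going by the values given here, compound 2 holds the only actual number so far, 16500 nM. The measured step is an at least 3.0-fold lower number from compound 1 to compound 2 (0.48 log units; beyond the scatter), which lies beyond the scatter.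

Compound 3 `CN(C)CCCCn1c(N)c(-c2nc3cc(Cl)ccc3[nH]2)c2nc(C#N)c(C#N)nc21` differs from compound 2 as follows: (dimethylamino)methyl in place of dimethylamino on a saturated chain carbon, three bonds along the chain from an aromatic nitrogen. Put another way, 3-(dimethylamino)propyl gives way to 4-(dimethylamino)butyl.

Among the compounds with values here, only one measured step bears on this change: the same exchange, made two bonds along the chain from an aromatic nitrogen. Its size is known only as a minimum because it starts from the limit of > 50000 nM in this assay, at which 1 of the 2 values shown sits. A single step is a thin guide, and nothing yet shows whether the trend continues. On the strength of an at least 3.0-fold lower number from compound 1 to compound 2 (0.48 log units; beyond the scatter), a modest further move toward a lower number is expected in this assay. The expected step is a 2.1-fold lower number from compound 2 to compound 3 (0.31 log units; beyond the scatter). For compound 3 the estimated value is 8000 nM, with an expected range of 2500 nM to 25000 nM.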

Compound 3, half-maximal inhibitory concentration: 3120 nM
For compound 3 the middle estimate is 2.6-fold (0.41 log units) above the measured one, within the range that was stated.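

Going by these compounds alone, the exchange made three bonds along the chain from an aromatic nitrogen gives the first step with a measured size at both ends: in this assay, there is a 5.3-fold lower number from compound 2 to compound 3 (0.72 log units; beyond the scatter). With it, the direction seen at the shorter chain holds for a second lengthening, so the number falls at each step among the three compounds, none going against this, and compound 3 is the strongest of them, though whether the second step exceeds the first cannot be said. Over the whole change from 2-(dimethylamino)ethyl-bearing compound 1 to the butyl chain there is an at least 16-fold lower number from compound 1 to compound 3 (1.20 log units; beyond the scatter), a size known only as a minimum because compound 1 stands at a limit of the assay and not at a number: the limit of > 50000 nM in this assay, at which 1 of the 3 values shown sits.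

As far as these compounds go, whether the trend goes on with a chain longer than 4-(dimethylamino)butyl, or levels off or turns back, remains open. Also open, from the compounds shown here alone, is how far the gain depends on the dimethylamino end itself, as opposed to the chain length alone, which a morpholine or a primary amine at the end of the same butyl chain would bear on.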